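A few compounds are considered here, and "the series" means these few. Any claim that something is new, unique, unknown or untested is made for them only; others in the source may bear on it.

The study describes a series of chromone acrylamides tested in a functional assay on Huh-7 cells (Homo sapiens) for inhibition, read by MTT assay, with a stated time of 48 h (a higher number here means a weaker inhibitor, a lower number a stronger inhibitor), on Huh-7 cells. Compound 1 `Cc1ccccc1NC(=O)/C=C/c1coc2cc(O)ccc2c1=O` carries a hydroxy group and a 2-methylphenyl amide, and in this assay compound 1 gives 11100 nM. Compound 2 `COc1ccc2c(=O)c(/C=C/C(=O)Nc3ccccc3C)coc2c1` differs from it only by a methyl on the ring oxygen; in this assay compound 2 gives 26900 nM. The change between them, (hydrogen in place of methyl on an oxygen on an aromatic ring), made a step of a 2.4-fold lower number from compound 2 to compound 1 (0.38 log units; beyond the scatter).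

Compound 3 `COc1ccc2c(=O)c(/C=C/C(=O)NCc3ccc(F)cc3F)coc2c1` shares the methoxy core of compound 2 but differs in the amide part, (2,4-difluorobenzyl in place of 2-methylphenyl on an amide-type nitrogen), and the step is an at least 3.7-fold higher number from compound 2 to compound 3 (0.57 log units; beyond the scatter). For compound 3 in this assay the result is only a limit, > 100000 nM, which is the limit (the limit of > 100000 nM in this assay, at which 1 of the 3 values shown sits).

Compound 4 `O=C(/C=C/c1coc2cc(O)ccc2c1=O)NCc1ccc(F)cc1F` has not been measured. It stands to compound 3 exactly as compound 1 stands to compound 2: the same change, (hydrogen in place of methyl on an oxygen on an aromatic ring), at the same place on the shared core. On that basis the step from compound 3 to compound 4 is expected to resemble the earlier one, an at least 1.6-fold lower number from compound 3 to compound 4 (0.22 log units; that floor lies within the scatter), though the starting point for compound 3 is only a limit, so the outcome for compound 4 may itself be reported as a limit. Compound 4 is therefore expected to give about 60000 nM in this assay, estimated between 25000 nM and 150000 nM.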

Compound 4, half-maximal inhibitory concentration: > 100000 nM
Compound 4: no number, only a limit; the forecaster's own chance of this, stated with the estimate: 40%; middle value at least 1.6-fold (0.22 log units) away from the limit.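

In this assay compound 4 gives > 100000 nM as a limit of the assay and not a number. Among these compounds, compound 3 also stands at a limit, so no step between compound 3 and compound 4 can be read: the limit of > 100000 nM in this assay, at which 2 of the 4 values shown sit. The compounds shown leave open whether hydroxy in place of methoxy changes the result with the 2,4-difluorobenzyl amide as it does with the 2-methylphenyl amide.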